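The compounds below may be only part of what the source reports. "The series", "measured", "known", "first", "only" and "open" are said of these compounds alone.

Working notes on the series. In an ADME assay on NCI/ADR-RES cells (Homo sapiens) for inhibition, read by MTT assay, with a stated time of 48 h (a lower number here means a stronger inhibitor, a higher number a weaker inhibitor), compound 1 `CC(=O)O[C@@H]1C[C@@H](OC(=O)c2ccccc2)/C(C)=C/[C@H]2[C@@H](OC(=O)c3ccccc3)[C@@H](C)[C@H](O)[C@]2(OC(C)=O)[C@H](O)[C@](C)(O)/C=C/C1(C)C` gives > 150000 nM, which is a limit of the assay and not a number. Compound 2 `CC(=O)O[C@@H]1C[C@@H](OC(=O)c2ccccc2)/C(C)=C/[C@H]2[C@@H](OC(=O)c3ccccc3)[C@@H](C)[C@H](OC(C)=O)[C@]2(OC(C)=O)[C@H](O)[C@](C)(O)/C=C/C1(C)C` differs from compound 1 by acetyl in place of hydrogen on an oxygen on a saturated carbon. In this assay compound 2 gives > 150000 nM, again a limit. The step that the two limits leave unreadable from compound 1 to compound 2 cannot be sized because both values sit at the limit of > 150000 nM in this assay, at which 2 of the 2 values shown sit. Compound 3 `CC(=O)O[C@@H]1C[C@@H](OC(=O)c2ccccc2)/C(C)=C/[C@H]2[C@@H](OC(=O)c3ccccc3)[C@@H](C)[C@H](OC(=O)c3ccccc3)[C@]2(OC(C)=O)[C@H](O)[C@](C)(O)/C=C/C1(C)C` carries the change benzoyl in place of hydrogen on an oxygen on a saturated carbon relative to compound 1, so a benzoyl now sits on the oxygen where compound 2 carries acetyl. Within the data shown here, the only measured step touching this oxygen is the one from compound 1 to compound 2, and it gives no readable size, so no step beyond the scatter is expected in this assay; the step of a number no higher from compound 1 to compound 3 (the limit leaves the size open) is an estimate only. Compound 3 is expected at 150000 nM, between 50000 nM and 500000 nM, most likely again reported as a limit.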

Compound 3, half-maximal inhibitory concentration: 64200 nM
Compound 3: the middle estimate sits 2.3-fold (0.37 log units) above what was measured, within the range that was stated.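

In this assay, among these compounds, benzoyl in place of hydrogen on this oxygen gives an at least 2.3-fold lower number from compound 1 to compound 3 (0.36 log units; beyond the scatter), the first readable change at this position. Phenyl in place of methyl on the carbonyl carbon gives an at least 2.3-fold lower number from compound 2 to compound 3 (0.36 log units; beyond the scatter), so the benzoyl ester at this oxygen separates from the acetyl ester, which the unreadable step between the two earlier compounds could not show. Both new steps give only a minimum size, since compound 1 and compound 2 each stand at a limit and not at a number: the limit of > 150000 nM in this assay, at which 2 of the 3 values shown sit.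

On these data alone, the true size of either step remains open, and so does whether the aromatic ring is what matters or any acyl group larger than acetyl would serve. A hexanoyl chain on the same oxygen, or a benzoyl carrying an amine on its ring, would bear on this.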